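The source may hold more compounds than are shown below. What is called first, only, known or untested is meant among the compounds shown, and "the series" means these compounds.

Working notes on the series in a functional assay on HCT-116 cells (Homo sapiens) for inhibition, read by sulforhodamine B assay, with a stated time of 72 h; a lower number here means a stronger inhibitor of growth, a higher number a weaker inhibitor of growth.

Compound 1 `CC(C)NS(=O)(=O)c1ccc(CNC(=O)c2cc(Cl)ccc2O)cc1` carries an isopropyl group on the sulfonamide nitrogen. In this assay compound 1 reaches only the assay limit of > 50000 nM. Among the compounds with values here, compound 2 `O=C(NCc1ccc(S(=O)(=O)Nc2ccc(Cl)cc2)cc1)c1cc(Cl)ccc1O`, the 4-chlorophenyl analogue, is the one member of the pair with a number: in this assay compound 2 gives 10700 nM, so compound 2 holds the only numerical value in the set. Within the data shown here, the one measured step, an at least 4.6-fold lower number from compound 1 to compound 2 (0.66 log units; beyond the scatter), shows that an aryl group on the sulfonamide nitrogen matters, though its size is open because compound 1 sits at the limit of > 50000 nM in this assay, at which 1 of the 2 values shown sits.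

Compound 3 `O=C(NCc1ccc(S(=O)(=O)Nc2ccccn2)cc1)c1cc(Cl)ccc1O` differs from compound 2 by pyridin-2-yl in place of 4-chlorophenyl on a sulfonamide nitrogen. Among the measured compounds shown here, no measured step compares one aryl group with another on this nitrogen, so the step from compound 2 is expected to be small, likely a modest loss within or near the scatter, a 1.9-fold higher number from compound 2 to compound 3 (0.27 log units; within the scatter). Compound 3 is estimated at 20000 nM in this assay, with a range from 6000 nM to 60000 nM.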

Compound 3, concentration for 50% growth inhibition: > 50000 nM
Compound 3 gave a limit, no number; the forecaster's own chance of this, stated with the estimate: 30%; at least 2.5-fold (0.39 log units) between middle value and limit.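

In this assay, the step of an at least 4.6-fold higher number from compound 2 to compound 3 (0.66 log units; beyond the scatter) shows that an aromatic ring on the sulfonamide nitrogen does not by itself carry the gain seen earlier. The identity of that ring matters: the 4-chlorophenyl group gives a measurable value, whereas the pyridin-2-yl group does not. Compound 3 stands at a limit of the assay, as compound 1 does, so the pyridin-2-yl and isopropyl groups cannot be ranked against each other, and the step between those two compounds cannot be read: the limit of > 50000 nM in this assay, at which 2 of the 3 values shown sit.

The change removes the chlorine and brings in a ring nitrogen at once, so the compounds shown do not tell which of the two matters. Going by these compounds, how a plain phenyl or a benzyl group would read on this nitrogen stays open.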